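This account rests on a few compounds, and the source may have more. Where it says the series, first, only, none or still open, it means among the compounds named here.

In an ADME assay on S9 fraction from liver (Mus musculus) for metabolic stability, read by LC-MS, using NADPH, with a stated time of 60 min, tested at 1 uM (a lower number here means that the compound disappears faster, a higher number that the compound lasts longer), compound 1 `Cc1ccccc1N(C)C(=O)c1ccc(-c2ccc(OS(N)(=O)=O)cc2)o1` gives 0.417 h as its half-life. Compound 3 `Cc1ccccc1N(C)C(=O)c1ccc(-c2ccc(OS(N)(=O)=O)cc2F)o1` gives 0.383 h and cannot be told apart from compound 1 on this measure, whereas compound 2 `Cc1ccccc1N(C)C(=O)c1ccc(-c2ccc(OS(N)(=O)=O)c(F)c2)o1` gives 0.102 h and lies clearly lower. Compound 1 therefore stands level with compound 3 and clearly above compound 2.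

Compound 4 `Cc1ccc(F)cc1N(C)C(=O)c1ccc(-c2ccc(OS(N)(=O)=O)cc2)o1` has not been measured yet. It differs from compound 1 by a single change fluoro in place of hydrogen on an aromatic carbon in which fluoro takes the place of hydrogen on an aromatic carbon, turning 2-methylphenyl into 5-fluoro-2-methylphenyl. The two measured steps make the same kind of swap, but elsewhere in the molecule and not on the 2-methylphenyl. The first gave a 4.1-fold lower number from compound 1 to compound 2 (0.61 log units; beyond the scatter) while the second gave a 1.1-fold lower number from compound 1 to compound 3 (0.04 log units; within the scatter) on the same measure. Going by the values given here, the same swap has thus produced both a clear drop and no real difference, and no measured compound carries it at the new place. On this evidence, no step beyond the scatter is expected, although a fall remains possible. The expected outcome is a 1.2-fold lower number from compound 1 to compound 4 (0.08 log units; within the scatter) as a best guess. Compound 4 is estimated at 0.35 h (expected range 0.13 h to 0.75 h).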

Compound 4, half-life: 0.065 h
Compound 4: the middle estimate sits 5.4-fold (0.73 log units) above what was measured; the whole stated range lies above it.
By their numbers in this assay, from the lowest: compounds 4 and 2 (each within the scatter of the next); then compounds 3 and 1 (each within the scatter of the next).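

On the 2-methylphenyl, placing fluoro para to the methyl group gives a 6.4-fold lower number from compound 1 to compound 4 (0.81 log units; beyond the scatter) in this assay, so a single added fluorine at this position is enough to shorten the half-life beyond the usual scatter. Going by these compounds alone, this is the first measured change on this ring, and it joins a 4.1-fold lower number from compound 1 to compound 2 (0.61 log units; beyond the scatter) as a second clear fall from the same kind of swap, while a 1.1-fold lower number from compound 1 to compound 3 (0.04 log units; within the scatter) goes against any rule that adding fluoro always shortens the half-life, so the outcome depends on where the fluoro sits. No measurement available here explains why the half-life falls at this position.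

From the compounds shown here alone, whether the fall is tied to fluoro or would also follow from another group at this position remains open, for instance with chloro, a methoxy group or a nitrile. Also unresolved is how fluoro would behave on the other aromatic carbons of the 2-methylphenyl, and whether the falls seen in compound 2 and compound 4 would combine in a single molecule carrying both fluoro groups.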